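The source may report more compounds than this note shows. Statements on the series, on what has been measured and on what is new or still open speak of the compounds shown alone.

Measured compounds:
compound 1, `O=C(Nc1cccc(-n2cc(-c3ccncc3)c(-c3ccc(Cl)c(O)c3)n2)c1)Nc1cccc(C(F)(F)F)c1`: 1400 nM
compound 2, `COc1cc(-c2nn(-c3cccc(NC(=O)c4cccc(C(F)(F)F)c4)c3)cc2-c2ccncc2)ccc1Cl`: 1450 nM
compound 3, `O=C(Nc1cccc(-n2cc(-c3ccncc3)c(-c3ccc(Cl)c(O)c3)n2)c1)Nc1ccc(Cl)c(Cl)c1`: 1030 nM

All three compounds were tested in a functional assay on CCRF-CEM cells (Homo sapiens) for inhibition, read by sulforhodamine B assay, with a stated time of 48 h; a lower number here means a stronger inhibitor of growth, a higher number a weaker inhibitor of growth. The numbers stand close together: compound 2 with 1450 nM sits within the usual scatter of compound 1 and of compound 3, so the three cannot be told apart on these measurements. Among the measured compounds shown here, the only step with a single change is the swap of the aryl group on the amide-type nitrogen, which gives a 1.4-fold lower number from compound 1 to compound 3 (0.13 log units; within the scatter) and stays within the scatter.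

Compound 4, `COc1cc(-c2nn(-c3cccc(NC(=O)Nc4cccc(C(F)(F)F)c4)c3)cc2-c2ccncc2)ccc1Cl`, has not yet been measured in this assay. It differs from compound 2 in one place: (3-(trifluoromethyl)phenyl)amino in place of 3-(trifluoromethyl)phenyl on a carbonyl carbon. In plain terms, the amide of compound 2 becomes a urea in compound 4, while the rest of the molecule stays the same. For the measured compounds named here, no measured pair shows exactly this amide-to-urea change on this core. Going by the values given here, compound 1 carries the same urea as compound 4 but differs from compound 2 in two places, so there is no direct step between them; the value of compound 1, 1400 nM, can only be set beside that of compound 2. Since both numbers lie within the scatter of one another, the expectation is a step of a 1.0-fold lower number from compound 2 to compound 4 (0.02 log units; within the scatter), that is, no change beyond the scatter. Compound 4 is therefore estimated at 1400 nM, with a range from 700 nM to 2800 nM.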

Compound 4, concentration for 50% growth inhibition: 945 nM
Compound 4: middle estimate off by 1.5-fold (0.17 log units), on the high side; the measured number falls inside the stated range.
By their numbers in this assay, from the lowest: compounds 4, 3, 1 and 2 (each within the scatter of the next).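

On a carbonyl carbon whose other neighbour is an amide-type nitrogen, (3-(trifluoromethyl)phenyl)amino in place of 3-(trifluoromethyl)phenyl turns the amide into a urea and adds one hydrogen-bond donor; in this assay this gives a 1.5-fold lower number from compound 2 to compound 4 (0.19 log units; within the scatter) and, being within the scatter, gives the first direct sign that this swap does not separate the two compounds. With the urea held constant, methyl in place of hydrogen on an oxygen on an aromatic ring gives a 1.5-fold lower number from compound 1 to compound 4 (0.17 log units; within the scatter) and is also within the scatter, so a free hydroxyl and a methoxy group cannot be told apart at this position in this pair. No measurement shown here accounts for these results.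

Going by these compounds, every group on the carbonyl side in these compounds still ends in a substituted phenyl ring, so it remains open whether a different kind of group there, such as a simple amine, a carboxylic acid or a longer alkyl chain, would give a step beyond the scatter. On these data alone, the oxygen on the aromatic ring is likewise open to larger groups, such as an ethyl or a longer chain in place of the methyl.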